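The source may hold more compounds than are shown below. What is called first, only, known or untested is meant among the compounds shown, and "the series" means these compounds.

In a functional assay on HL-60 cells (Homo sapiens) for antiproliferative activity, read by MTT assay, with a stated time of 72 h (a higher number here means a weaker inhibitor of growth, a lower number a stronger inhibitor of growth), compound 1 `C/C1=C/CC[C@@]2(C)O[C@@H]2[C@H]2OC(=O)[C@@H](CN3CCCCC3)[C@@H]2CC1` gives 3990 nM, compound 2 `C/C1=C/CC[C@@]2(C)O[C@@H]2[C@H]2OC(=O)[C@@H](CN3CCC(F)CC3)[C@@H]2CC1` gives 5700 nM and compound 3 `C/C1=C\CC[C@@]2(C)O[C@@H]2[C@H]2OC(=O)[C@@H](CN3CCC(F)(F)CC3)[C@@H]2CC1` gives 5580 nM. Compound 2 thus lies within the scatter of both other compounds. Compound 4 `C/C1=C/CC[C@@]2(C)O[C@@H]2[C@H]2OC(=O)[C@@H](CN3CCC(C(F)(F)F)CC3)[C@@H]2CC1` carries trifluoromethyl in place of fluoro on a saturated ring carbon. Going by the values given here, the one measured step that bears on this change, fluoro in place of hydrogen on a saturated ring carbon, is a 1.4-fold higher number from compound 1 to compound 2 (0.15 log units; within the scatter), which stays within the scatter. On the strength of that small step, no shift beyond the scatter is expected in this assay. The expected step is a 1.0-fold lower number from compound 2 to compound 4 (0.02 log units; within the scatter). For compound 4 the estimated value is 5500 nM, with an expected range from 3000 nM to 10000 nM.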

Compound 4, concentration for total growth inhibition: 2140 nM
Beside the measured number, compound 4's estimate is 2.6-fold (0.41 log units) above it; the whole stated range lies above it.
By their numbers in this assay, from the lowest: compounds 4, 1, 3 and 2 (each within the scatter of the next, the first and the last beyond it).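

At this position, three ring bonds from the ring nitrogen, the choice of group can move the result in this assay beyond the scatter, which the step from hydrogen to fluoro had not shown: trifluoromethyl in place of fluoro gives a 2.7-fold lower number from compound 2 to compound 4 (0.43 log units; beyond the scatter). Trifluoromethyl in place of hydrogen, by contrast, gives a 1.9-fold lower number from compound 1 to compound 4 (0.27 log units; within the scatter), which stays within the scatter, so the clear separation holds only against fluoro. Nothing available here accounts for this difference.

Going by these compounds, whether a methyl group, a longer chain or a carboxylic acid on the same ring carbon would track with trifluoromethyl or with fluoro remains open. So does whether the separation between compound 2 and compound 4 extends to other cell lines.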